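Dropping the phenol next door to an acid: expected clearance

The compounds below may be only part of what the source reports. "The series", "measured", "known", "first", "only" and "open" are said of these compounds alone.

Of the compounds shown here, three sharing one core have been measured in an ADME assay on microsomes from liver (Mus musculus) for metabolic stability, using NADPH, with a stated time of 60 min, in the presence of a further agent that is not named here; a higher number here means faster removal of the compound, a lower number slower removal. Compound 1 `O=C(O)COc1ccc([C@H]2CC[C@]3(CC2)OOC2(O3)C3CC4CC(C3)CC2C4)cc1C(=O)O` gives 8 mL.min-1.g-1. Compound 2 `O=C(O)COc1ccc([C@H]2CC[C@]3(CC2)OOC2(O3)C3CC4CC2CC(C3)C4(F)F)cc1` gives 130 mL.min-1.g-1. Compound 3 `O=C(O)c1cc([C@H]2CC[C@]3(CC2)OOC2(O3)C3CC4CC(C3)CC2C4)ccc1O` gives 20 mL.min-1.g-1, which places it second highest of the three, with compound 1 a little lower and compound 2 well above it. Among the compounds with values here, the only single-change step among them runs a 2.5-fold higher number from compound 1 to compound 3 (0.40 log units; beyond the scatter), a modest rise.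

Compound 4 `O=C(O)c1cccc([C@H]2CC[C@]3(CC2)OOC2(O3)C3CC4CC(C3)CC2C4)c1` differs from compound 3 by one change: hydrogen in place of hydroxy on an aromatic carbon. Within the data shown here, no measured step removes a hydroxy from this ring, so the step from compound 1 to compound 3 is only a loose guide; it shows that trimming a group on this ring moved this assay by a modest amount, and a change of similar or smaller size is expected here. The number for compound 4 is therefore expected to be 30 mL.min-1.g-1, within 10 mL.min-1.g-1 to 90 mL.min-1.g-1, a step of a 1.5-fold higher number from compound 3 to compound 4 (0.18 log units; within the scatter) that may well sit inside the scatter.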

Compound 4, intrinsic clearance in microsomes in the Mus musculus assay: 30 mL.min-1.g-1
Estimate against measurement, compound 4: no gap at the digits printed, and the stated range covers the measured number.
By their numbers in the Mus musculus assay, from the lowest: compound 1; then compounds 3 and 4 (each within the scatter of the next); then compound 2.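

In the Mus musculus assay, the hydroxy ortho to a carboxy group can be replaced by hydrogen with no change beyond the scatter, with a 1.5-fold higher number from compound 3 to compound 4 (0.18 log units; within the scatter), and the step that replaces the carboxymethoxy group stays modest, with a 3.8-fold higher number from compound 1 to compound 4 (0.57 log units; beyond the scatter). In a physicochemical assay for solubility, read by nephelometry, measured as kinetic solubility, with a stated time of 30 min, at pH 2.0 (on this read-out higher numbers stand for higher solubility and lower numbers for lower solubility), compound 3 gives > 100 ug/mL, which is a limit of the assay and not a number. In the physicochemical assay, compound 4 gives < 1.6 ug/mL, also a limit, so at this position the hydroxy matters far more for solubility than for clearance: the limit of < 1.6 ug/mL in the physicochemical assay, at which 1 of the 2 values shown sits.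

Both solubility values are limits, so the true size of that step cannot be read. On these data alone, whether an amine or a methoxy group at this position would give solubility like that of compound 3 stays open.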